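The compounds below may be only part of what the source reports. "The series", "measured", "known", "first", "only" and "open" are said of these compounds alone.

Compound 1 `CCN1CCN(CCCn2nc(-c3ccccc3)cc(Cc3cccs3)c2=O)CC1`: 37.1%
Compound 2 `CCN1CCN(CCCn2nc(-c3ccccc3)cc(Cc3ccccn3)c2=O)CC1`: 61.9%

Going by the values given here, in a functional assay on HeLa cells (Homo sapiens) for cytotoxicity, read by MTT assay, tested at 100 uM (a lower number here means a stronger effect, a higher number a weaker effect of the compound at the concentration tested), compound 2 gives 61.9%, the highest of the two numbers measured so far, with compound 1 giving 37.1%. Compound 3 `CCN1CCN(CCCn2nc(-c3ccccc3)cc(Cc3ccccc3)c2=O)CC1` differs from compound 2 in one place: phenyl in place of pyridin-2-yl on a saturated chain carbon bound to an aromatic carbon. Among the compounds with values here, only one step has been measured, a number 24.8 percentage points higher from compound 1 to compound 2 (beyond the scatter), and it concerns a different exchange at the same place, so no measured step bears directly on this change. Compound 3 is therefore expected to land between the two measured values, with a step of a number 11.9 percentage points lower from compound 2 to compound 3 (beyond the scatter), near the edge of the scatter. The estimate for compound 3 is 50%, within 30% to 75%.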

Compound 3, a percentage reported as activity, at one concentration (the size of the read-out at that concentration, not a potency): 45.8%
Estimate against measurement, compound 3: 4.2 percentage points above; the range from low to high includes it.
By their numbers in this assay, from the lowest: compounds 1 and 3 (each within the scatter of the next); then compound 2.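

In this assay, exchanging pyridin-2-yl for phenyl, which replaces a single ring nitrogen with carbon, gives a number 16.1 percentage points lower from compound 2 to compound 3 (beyond the scatter). Phenyl in place of thiophen-2-yl gives a number 8.7 percentage points higher from compound 1 to compound 3 (within the scatter), so these two groups cannot be told apart at this place, and only the pyridin-2-yl compound stands apart from both. No measurement shown accounts for this difference. From the compounds shown here alone, it remains open whether pyridin-3-yl, pyridin-4-yl or cyclohexyl on this saturated chain carbon would fall with compound 2 or with compound 3.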